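A few compounds are considered here, and "the series" means these few. Any claim that something is new, unique, unknown or untested is made for them only; others in the source may bear on it.

For the measured compounds named here, in an ADME assay on CHO cells (Cricetulus griseus) for cytotoxicity (a lower number here means a stronger inhibitor, a higher number a weaker inhibitor), compound 2 `Cc1nnc(/C(=N\O)c2nc3ccccc3s2)s1` gives 38000 nM, the only plain number in this small set. Compound 3 `O/N=C(\c1ccc2ncsc2c1)c1nc2ccccc2s1` gives > 50000 nM in this assay, which is a limit and not a number. For compound 1 `O/N=C/c1nc2ccccc2s1` this assay gives "not determined" (no result reported). Beyond the one firm value, the limit of > 50000 nM in this assay, at which 1 of the 3 values shown sits, is the only other mark. Compound 4 `O/N=C(/c1nc2ccccc2s1)C1CCCCC1` differs from compound 2 by cyclohexyl in place of 5-methyl-1,3,4-thiadiazol-2-yl on a carbon with a double bond to nitrogen. Going by the values given here, no step between two measured compounds is known, so the size of this change cannot be read off an earlier pair. The step of a 1.3-fold lower number from compound 2 to compound 4 (0.10 log units; within the scatter) is expected to stay within the scatter. The estimate for compound 4 in this assay is 30000 nM, between 10000 nM and 80000 nM.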

Compound 4, half-maximal inhibitory concentration: 51600 nM
Compound 4: the middle estimate sits 1.7-fold (0.24 log units) below what was measured, within the range that was stated.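

In this assay, cyclohexyl in place of 5-methyl-1,3,4-thiadiazol-2-yl on a carbon with a double bond to nitrogen gives a 1.4-fold higher number from compound 2 to compound 4 (0.13 log units; within the scatter). At this position, a non-aromatic ring of carbon only and a five-membered aromatic ring with 3 hetero atoms therefore cannot be told apart in this measurement. Compound 3 carries a limit and not a number: the limit of > 50000 nM in this assay, at which 1 of the 4 values shown sits.

Going by these compounds, whether an amine or a carboxylic acid at this position would shift the number beyond the scatter remains open. A single step cannot show how other groups would behave here.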